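From phenyl to 4-fluorophenyl on a bromo compound

The source may report more compounds than this note shows. Statements on the series, on what has been measured and on what is new or still open speak of the compounds shown alone.

In a functional assay on MCF7 cells (Homo sapiens) for antiproliferative activity, read by MTT assay, with a stated time of 48 h (on this read-out higher numbers stand for weaker inhibition and lower numbers for stronger inhibition), three compounds on a shared core have been measured. Compound 1 `Clc1ccc2[nH]c(-c3cn(-c4ccccc4)nc3-c3ccccc3)nc2c1` with chloro gives 1960 nM on this read-out. Compound 2 `Brc1ccc2[nH]c(-c3cn(-c4ccccc4)nc3-c3ccccc3)nc2c1` with bromo gives 830 nM and compound 3 `COc1ccc2[nH]c(-c3cn(-c4ccccc4)nc3-c3ccccc3)nc2c1` with methoxy gives 1590 nM under the same conditions. Among the measured compounds shown here, compound 2 stands modestly clear of the chloro compound, with a 2.4-fold lower number from compound 1 to compound 2 (0.37 log units; beyond the scatter) as the only step beyond the scatter, whereas a 1.9-fold higher number from compound 2 to compound 3 (0.28 log units; within the scatter) leaves it level with the methoxy compound. The remaining step of a 1.2-fold lower number from compound 1 to compound 3 (0.09 log units; within the scatter) also stays within the scatter.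

Compound 4 `Fc1ccc(-c2nn(-c3ccccc3)cc2-c2nc3cc(Br)ccc3[nH]2)cc1` keeps the bromo of compound 2 and alters another part of the molecule: fluoro in place of hydrogen on an aromatic carbon turns a phenyl into 4-fluorophenyl, with fluoro in place of hydrogen on an aromatic carbon, para to a large group. For the measured compounds named here, none of the measured steps touches this place, so they bear on it only indirectly, and the largest among them, a 2.4-fold lower number from compound 1 to compound 2 (0.37 log units; beyond the scatter), is modest. Going by the values given here, the data hold no precedent for fluoro. No step beyond the scatter is therefore expected in this assay, and no direction is favoured. The expected change is a 1.0-fold lower number from compound 2 to compound 4 (0.02 log units; within the scatter) in size. Compound 4 is expected at about 800 nM, with an estimated range from 300 nM to 2100 nM for the measurement.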

Compound 4, half-maximal inhibitory concentration: 3210 nM
Estimate against measurement, compound 4: 4.0-fold (0.60 log units) below, and the stated range ends below it.
By their numbers in this assay, from the lowest: compounds 2, 3, 1 and 4 (each within the scatter of the next, the first and the last beyond it).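

Among the compounds shown here, the first step at this place goes in one direction: in this assay, turning the phenyl into 4-fluorophenyl on the bromo compound gives a 3.9-fold higher number from compound 2 to compound 4 (0.59 log units; beyond the scatter), which means weaker inhibition. The earlier compounds shown here varied only the bromo, chloro or methoxy substituent and left this phenyl unchanged, so they could not show that a single fluoro on an aromatic carbon, para to a large group, is enough to move the read-out beyond the scatter. Nothing in the available data accounts for this shift in terms of how fluoro acts at this place.

The compounds shown leave open whether the weaker inhibition is particular to fluoro or would also follow from another group at this place, such as a methyl, a hydroxyl or an amine. They also leave open whether the same change would have a comparable effect on the chloro compound or the methoxy compound, since the step has been read only with bromo on the shared core.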